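A few compounds are considered here, and "the series" means these few. Any claim that something is new, unique, unknown or untested is made for them only; others in the source may bear on it.

Measured in a functional assay on MCF7 cells (Homo sapiens) for antiproliferative activity, with a stated time of 5 days (a lower number here means a stronger inhibitor, a higher number a weaker inhibitor), so far:
- compound 1 `CCCCc1ccc2[nH]c(-c3ccc(OC)cc3)c(/C=N/NC(=O)c3ccncc3)c2c1` gives 69 nM 
- compound 2 `CCCCc1ccc2[nH]c(-c3ccc(C(F)(F)F)cc3)c(/C=N/NC(=O)c3ccncc3)c2c1` gives 100 nM 

Compound 2 stands within the scatter of compound 1, so these two numbers give no order. The next change leads to compound 3 `CCCCc1ccc2[nH]c(-c3ccc(CC)cc3)c(/C=N/NC(=O)c3ccncc3)c2c1` with ethyl in place of trifluoromethyl on an aromatic carbon, counted as ethyl in place of trifluoromethyl on an aromatic carbon in full. Among the measured compounds shown here, one measured step bears on this place: a 1.4-fold higher number from compound 1 to compound 2 (0.16 log units; within the scatter) for trifluoromethyl in place of methoxy. No shift beyond the scatter is therefore expected in this assay for the new group. The estimate is a 1.3-fold lower number from compound 2 to compound 3 (0.10 log units; within the scatter) on this basis. For compound 3 the estimated value is 80 nM with an expected range from 40 nM to 160 nM in this assay.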

Compound 3, half-maximal inhibitory concentration: 150 nM
Beside the measured number, compound 3's estimate is 1.9-fold (0.27 log units) below it, and the stated range covers the measured number.
By their numbers in this assay, from the lowest: compounds 1, 2 and 3 (each within the scatter of the next, the first and the last beyond it).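

In this assay ethyl in place of trifluoromethyl at this position gives a 1.5-fold higher number from compound 2 to compound 3 (0.18 log units; within the scatter) and so does not separate the two groups. Ethyl in place of methoxy gives a 2.2-fold higher number from compound 1 to compound 3 (0.34 log units; beyond the scatter) as the first step beyond the scatter in the series, a modest one, while trifluoromethyl stays within the scatter of both. Nothing on hand accounts for this step.

On these data alone, whether an amine or a carboxylic acid at this position would shift the number more remains open. So does the effect of a longer chain in place of ethyl.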